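This account rests on a few compounds, and the source may have more. Where it says the series, first, only, none or still open, it means among the compounds named here.

Compound 1, `O=C(c1ccc(-c2ccccc2)cc1)N1CCCN(C(=O)c2ccc3cc[nH]c3c2)CC1`: 6500 nM
Compound 2, `Cc1ccccc1-c1ccc(C(=O)N2CCN(C(=O)c3ccc4cc[nH]c4c3)[C@@H](C)C2)cc1F`: 9 nM

In a functional assay on CHO-K1 cells for antagonist activity at growth hormone secretagogue receptor type 1 (Homo sapiens), read by luminescence and calcium flux (on this read-out lower numbers stand for stronger inhibition and higher numbers for weaker inhibition), compound 2 holds the lowest number of the two measured, and compound 1 sits far higher, well beyond the scatter of repeated measurements. Compound 3, `C[C@H]1CN(C(=O)c2ccc(-c3ccncc3)c(F)c2)CCN1C(=O)c1ccc2cc[nH]c2c1`, has not yet been tested in this assay. It differs from compound 2 in one place: pyridin-4-yl in place of 2-methylphenyl on an aromatic carbon. Among the measured compounds shown here, no measured pair shows this exact change, so the direction rests on judgement; a loss of potency beyond the scatter seems likelier than a gain. Compound 3 is therefore expected to give 80 nM, within a range of 15 nM to 500 nM. That estimate means an expected step of an 8.9-fold higher number from compound 2 to compound 3 (0.95 log units; beyond the scatter).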

Compound 3, half-maximal inhibitory concentration: 12.2 nM
The estimate for compound 3 lay 6.6-fold (0.82 log units) above the measured number; the measured number lies below the stated range.
By their numbers in this assay, from the lowest: compounds 2 and 3 (each within the scatter of the next); then compound 1.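

In this assay, pyridin-4-yl in place of 2-methylphenyl, on the aromatic carbon ortho to a fluoro group, gives a 1.4-fold higher number from compound 2 to compound 3 (0.13 log units; within the scatter) and leaves the two compounds indistinguishable. This position can therefore carry either a carbon-only ring bearing a methyl group or a ring containing one nitrogen, with similar potency. Nothing measured here explains this similarity.

From the compounds shown here alone, whether a nitrile or a morpholine would also be accepted at this position stays open. Compound 1 differs from compound 2 in more than one place, so its far higher number cannot be assigned to any single feature.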